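The compounds below may be only part of what the source reports. "The series", "measured", "known", "first", "only" and "open" are said of these compounds alone.

Measured so far in a functional assay on NCI-H460 cells (Homo sapiens) for antiproliferative activity, read by MTT assay, with a stated time of 48 h; a higher number here means a weaker inhibitor, a lower number a stronger inhibitor:
Compound 1 `CCCCCCCCO[C@@H]1O[C@@H](C)[C@H](OC(=O)CCCCC)[C@@H](O[C@@H]2O[C@@H](C)[C@H](OC(C)=O)[C@@H](O)[C@H]2OC(C)=O)[C@H]1O` gives > 500000 nM, which is a limit of the assay rather than a number.
Compound 2 `CCCCCCCCO[C@@H]1O[C@@H](C)[C@H](OC(=O)CCCCC)[C@@H](O[C@@H]2O[C@@H](C)[C@H](OC(C)=O)[C@@H](O[C@@H]3O[C@@H](C)[C@H](O)[C@@H](O)[C@H]3OC(C)=O)[C@H]2OC(C)=O)[C@H]1O` gives 24000 nM.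
Compound 3 `CCCCCCCCO[C@@H]1O[C@@H](C)[C@H](OC(=O)CCCCC)[C@@H](O[C@@H]2O[C@@H](C)[C@H](O)[C@@H](OC(C)=O)[C@H]2OC(C)=O)[C@H]1O` gives 151000 nM.

Compound 1 therefore stands only at the limit, where (the limit of > 500000 nM in this assay, at which 1 of the 3 values shown sits); the other two compounds each give a number. Going by the values given here, no two measured compounds differ in a single place, so no measured step guides the next estimate. Compound 4 `CCCCCCCCO[C@@H]1O[C@@H](C)[C@H](OC(=O)CCCCC)[C@@H](O[C@@H]2O[C@@H](C)[C@H](OC(C)=O)[C@@H](OC(=O)CC(C)C)[C@H]2OC(C)=O)[C@H]1O` differs from compound 1 by isobutylcarbonyl in place of hydrogen on an oxygen on a saturated carbon. Compound 3 gives 151000 nM and compound 2 gives 24000 nM. Compound 1, by contrast, offers only a limit. The step of an at least 5.0-fold lower number from compound 1 to compound 4 (0.69 log units; beyond the scatter) is therefore expected to be a gain beyond the scatter. Compound 4 is estimated at 100000 nM, within 30000 nM to 400000 nM.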

Compound 4, half-maximal inhibitory concentration: 79000 nM
Compound 4: the middle estimate sits 1.3-fold (0.10 log units) above what was measured, within the range that was stated.
By their numbers in this assay, from the lowest: compound 2; then compounds 4 and 3 (each within the scatter of the next). At a limit, above all of these: compound 1.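

In this assay, the change from hydroxy to (isobutylcarbonyl)oxy, on an oxygen on a saturated carbon, gives an at least 6.3-fold lower number from compound 1 to compound 4 (0.80 log units; beyond the scatter). The true size of this step cannot be read, since compound 1 stands only at a limit: the limit of > 500000 nM in this assay, at which 1 of the 4 values shown sits. The free hydroxy is thus not needed at this position for a measurable value, as compound 4 gives 79000 nM.

The compounds shown leave open whether a longer straight acyl chain or an amine at this position would give a similar value.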